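Working notes on mouse exposure, compounds 1 to 3

The source may report more compounds than this note shows. Statements on the series, on what has been measured and on what is new or still open speak of the compounds shown alone.

Measured compounds:
compound 1 `Cc1cn(-c2cc(NC(=O)c3ccc(C)c(Nc4nccc(-c5ccccc5)n4)c3)cc(N3CCNCC3)c2)cn1` gives 116 ng.h/mL
compound 2 `Cc1cn(-c2cc(CN3CCN(C)CC3)cc(NC(=O)c3ccc(C)c(Nc4nccc(-c5ccccc5)n4)c3)c2)cn1` gives 166 ng.h/mL

In an ADME assay on the whole organism (Mus musculus, strain CD1), read by LC-MS, using cassette dosing, with a stated time of 24 h, at a dose of 0.4 mg/kg by the intravenous route (on this read-out higher numbers stand for higher exposure at the dose given and lower numbers for lower exposure), compound 2 gives 166 ng.h/mL; the step of a 1.4-fold higher number from compound 1 to compound 2 (0.16 log units; within the scatter) leaves compound 2 and compound 1 within the scatter of each other, so neither stands apart. Compound 3 `Cc1cn(-c2cc(CCS(N)(=O)=O)cc(NC(=O)c3ccc(C)c(Nc4nccc(-c5ccccc5)n4)c3)c2)cn1` differs from compound 2 by sulfamoylmethyl in place of 4-methylpiperazin-1-yl on a saturated chain carbon bound to an aromatic carbon. For the measured compounds named here, no measured step removes the ring or brings in sulfamoylmethyl; the one step known, a 1.4-fold higher number from compound 1 to compound 2 (0.16 log units; within the scatter), touched the same position but kept the ring, and was small. On that thin basis, the expected step is a 1.3-fold lower number from compound 2 to compound 3 (0.11 log units; within the scatter), with wide uncertainty. Compound 3 is estimated at 130 ng.h/mL, between 35 ng.h/mL and 450 ng.h/mL.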

Compound 3, area under the concentration-time curve: 58.5 ng.h/mL
Compound 3: the middle estimate sits 2.2-fold (0.35 log units) above what was measured; the range from low to high includes it.
By their numbers in this assay, from the lowest: compounds 3, 1 and 2 (each within the scatter of the next, the first and the last beyond it).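

Within this assay, a 2.8-fold lower number from compound 2 to compound 3 (0.45 log units; beyond the scatter) is the only step in this set beyond the scatter, so exchanging 4-methylpiperazin-1-yl for sulfamoylmethyl on a saturated chain carbon bound to an aromatic carbon can move exposure, if only modestly. The other comparison, a 2.0-fold lower number from compound 1 to compound 3 (0.30 log units; within the scatter), remains within the scatter, so 2-sulfamoylethyl stands clearly apart from (4-methylpiperazin-1-yl)methyl only, and not from piperazin-1-yl. No available evidence bears on what lies behind this step.

Open, going by these compounds, is whether the step follows the loss of the ring or the entry of sulfamoylmethyl. A simple amine or a carboxylic acid in the same place would help to separate the two.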